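Series notes: longer sulfur chain, from compound 3 to compound 4

A few compounds are considered here, and "the series" means these few. Any claim that something is new, unique, unknown or untested is made for them only; others in the source may bear on it.

Three compounds share a core: compound 1 `CN(C)C(=S)SC(=S)N1CCN(c2ccccc2)CC1`, compound 2 `CN(C)C(=S)SC(=S)N1CCN(C(=O)c2ccco2)CC1` and compound 3 `CSC(=S)N1CCN(C(=S)SC(=S)N(C)C)CC1`. In an ADME assay on HeLa cells (Homo sapiens) for cytotoxicity, read by MTT assay, with a stated time of 24 h (a higher number here means a weaker inhibitor, a lower number a stronger inhibitor), compound 1 gives 1610000 nM and compound 2 gives 2380000 nM; the step of a 1.5-fold higher number from compound 1 to compound 2 (0.17 log units; within the scatter) lies within the scatter. Compound 3 reaches only the limit of this assay, > 5000000 nM, and not a number. The steps of an at least 3.1-fold higher number from compound 1 to compound 3 (0.49 log units; beyond the scatter) and an at least 2.1-fold higher number from compound 2 to compound 3 (0.32 log units; beyond the scatter) are both beyond the scatter, so compound 3 stands as the weakest of the three, at the limit of > 5000000 nM in this assay, at which 1 of the 3 values shown sits.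

Compound 4 `CCSC(=S)N1CCN(C(=S)SC(=S)N(C)C)CC1` differs from compound 3 by methyl in place of hydrogen on a saturated chain carbon bound to a sulfur. Among the compounds with values here, none of the measured steps touches this part of the structure; the two steps that end in compound 3 exchange the group on the ring amine nitrogen and carry no information about a longer chain on the sulfur. In this assay no step beyond the scatter is therefore expected, a number no higher from compound 3 to compound 4 (the limit leaves the size open), and compound 4 is most likely to remain at the same limit. Compound 4 is estimated at 5000000 nM, with a range from 2500000 nM to 10000000 nM.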

Compound 4, half-maximal inhibitory concentration: 4480000 nM
For compound 4 the middle estimate is 1.1-fold (0.05 log units) above the measured one, within the range that was stated.
By their numbers in this assay, from the lowest: compounds 1, 2 and 4 (each within the scatter of the next, the first and the last beyond it). At a limit, above all of these: compound 3.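

In this assay, replacing methylsulfanyl with ethylsulfanyl gives this position its first measured number, whereas compound 3 stands only at a limit: the limit of > 5000000 nM in this assay, at which 1 of the 4 values shown sits.

With an at least 1.1-fold lower number from compound 3 to compound 4 (0.04 log units; that floor lies within the scatter), the added methyl has no readable size, and only its floor is known. Within the data shown here, compound 4 also allows the first numerical comparisons of this sulfur-bearing group on the ring amine nitrogen with the earlier groups: a 1.9-fold higher number from compound 2 to compound 4 (0.27 log units; within the scatter) separates it from the (furan-2-yl)carbonyl compound by no more than the scatter, while a 2.8-fold higher number from compound 1 to compound 4 (0.44 log units; beyond the scatter) sets it modestly apart from the phenyl compound.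

From the compounds shown here alone, whether a propyl or longer chain on the sulfur would move the number beyond the scatter remains open. So does the effect of an amine or a carboxylic acid at the end of that chain.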